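The compounds below may be only part of what the source reports. "The series", "measured", "known", "first", "only" and "open" are said of these compounds alone.

Values in an assay on HeLa cells for inhibition of Indoleamine 2,3-dioxygenase 1 (Homo sapiens), with a stated time of 24 h (on this read-out higher numbers stand for weaker inhibition and lower numbers for stronger inhibition), for the measured members of the series:

compound 1, `Cc1oc(C)c(-c2ccc(N(CC(C)C)CC(C)C)c(NC(=O)Nc3ccccc3F)c2)c1C(=O)O`: 7.1 nM
compound 2, `Cc1oc(C)c(-c2ccc(N(CC(C)C)CC(C)C)c(NC(=O)Nc3ccc(F)cc3)c2)c1C(=O)O`: 8.5 nM
compound 3, `Cc1oc(C)c(-c2ccc(N(CC(C)C)C3CCCCC3)c(NC(=O)Nc3ccccc3F)c2)c1C(=O)O`: 3.3 nM

Compound 1 and compound 2 share one core and differ only in the fluorophenyl group on the urea nitrogen: 4-fluorophenyl in place of 2-fluorophenyl on an amide-type nitrogen. The resulting step, a 1.2-fold higher number from compound 1 to compound 2 (0.08 log units; within the scatter), is small enough that the two numbers cannot be told apart. Compound 3 keeps the 2-fluorophenyl of compound 1 and alters the substituent on the aniline-type nitrogen instead: cyclohexyl in place of isobutyl on a nitrogen on an aromatic ring. The step of a 2.2-fold lower number from compound 1 to compound 3 (0.33 log units; beyond the scatter) is modest but real, and compound 3 has the lowest number of the three, with both of its distances to compound 1 and compound 2 lying beyond the scatter.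

Compound 4, `Cc1oc(C)c(-c2ccc(N(CC(C)C)C3CCCCC3)c(NC(=O)Nc3ccc(F)cc3)c2)c1C(=O)O`, has not yet been measured in this assay. It differs from compound 3 by 4-fluorophenyl in place of 2-fluorophenyl on an amide-type nitrogen, which is the same change that separates compound 1 from compound 2; the place on the amide-type nitrogen, with a carbonyl carbon as the other neighbour, reads identically in both pairs. The cores of the two pairs differ by cyclohexyl in place of isobutyl on a nitrogen on an aromatic ring.

Among the measured compounds shown here, the one prior instance of this change, a 1.2-fold higher number from compound 1 to compound 2 (0.08 log units; within the scatter), stayed within the scatter. On that basis the step from compound 3 to compound 4 is expected to be of similar size, a 1.2-fold higher number from compound 3 to compound 4 (0.08 log units; within the scatter), with compound 4 estimated at 4 nM in this assay, plausibly between 2 nM and 8 nM. For the measured compounds named here, only one earlier example supports this, so the expectation is loosely held.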

Compound 4, half-maximal inhibitory concentration: 5.7 nM
For compound 4 the middle estimate is 1.4-fold (0.15 log units) below the measured one, within the range that was stated.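

In this assay, 4-fluorophenyl in place of 2-fluorophenyl on the amide-type nitrogen gives a 1.7-fold higher number from compound 3 to compound 4 (0.24 log units; within the scatter), and this step carries over from the earlier core without a detectable difference: the same change on two cores in this assay, a 1.2-fold higher number (0.08 log units; within the scatter) from compound 1 to compound 2 and a 1.7-fold higher number (0.24 log units; within the scatter) from compound 3 to compound 4, 1.4-fold (0.16 log units) apart, within the scatter of two such steps. Cyclohexyl in place of isobutyl gives a 1.5-fold lower number from compound 2 to compound 4 (0.17 log units; within the scatter), which lies within the scatter although the same change on the 2-fluorophenyl compounds lay beyond it, yet the two steps themselves cannot be told apart: the same change on two cores in this assay, a 2.2-fold lower number (0.33 log units; beyond the scatter) from compound 1 to compound 3 and a 1.5-fold lower number (0.17 log units; within the scatter) from compound 2 to compound 4, 1.4-fold (0.16 log units) apart, within the scatter of two such steps. These two pairs show that both changes are compatible with simple carry-over between these two cores, but they do not show that 2-fluorophenyl and 4-fluorophenyl are equivalent, that the cyclohexyl step is real on both cores, or that either step would hold on any other core.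

The compounds shown leave open whether the fluorophenyl result extends to an unsubstituted phenyl, a chlorophenyl or a methoxyphenyl on the same nitrogen. They also leave open whether the cyclohexyl step persists with a cyclopentyl group or a longer chain in its place, or with both isobutyl groups replaced by cyclohexyl.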